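A few compounds are considered here, and "the series" means these few. Any claim that something is new, unique, unknown or untested is made for them only; others in the source may bear on it.

Compound 1 `CC(C)(C)OC(=O)Nc1cccc(-c2csc(NC(=O)CCCCCC(=O)NO)n2)c1` gives the lowest number of the three measured compounds: in an assay on isolated protein for inhibition of polyamine deacetylase HDAC10 (Homo sapiens), read by fluorescence, with a stated time of 17 h (a higher number here means a weaker inhibitor, a lower number a stronger inhibitor), compound 1 gives 5.7 nM. Compound 2 `CC(C)(C)OC(=O)Nc1cccc(-c2csc(NC(=O)CCCCCC(=O)Nc3ccccc3N)n2)c1` gives 5300 nM in this assay, and the change from hydroxy to 2-aminophenyl on the amide-type nitrogen brought a 930-fold higher number from compound 1 to compound 2 (2.97 log units; beyond the scatter). Compound 3 `CCOC(=O)Nc1cccc(-c2csc(NC(=O)CCCCCC(=O)Nc3ccccc3N)n2)c1` stands at > 30000 nM in this assay, which is a limit of the assay and not a number. Because compound 3 sits at the limit of > 30000 nM in this assay, at which 1 of the 3 values shown sits, the step of an at least 5.6-fold higher number from compound 2 to compound 3 (0.75 log units; beyond the scatter) is known only as a lower bound.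

Compound 4 `CCOC(=O)Nc1cccc(-c2csc(NC(=O)CCCCCC(=O)NO)n2)c1` has not yet been measured. It differs from compound 3 by hydroxy in place of 2-aminophenyl on an amide-type nitrogen, the same exchange that separates compound 2 from compound 1, run in the opposite direction. That earlier step was large, so a large fall in the number is expected here, tempered by the ethyl carbamate, whose cost in the measured pair was an at least 5.6-fold higher number from compound 2 to compound 3 (0.75 log units; beyond the scatter). The expected step is an at least 1200-fold lower number from compound 3 to compound 4 (3.07 log units; beyond the scatter). Compound 4 is therefore estimated to give 25 nM in this assay, within a range of 5 nM to 150 nM.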

Compound 4, half-maximal inhibitory concentration: 2.1 nM
Compound 4: middle estimate off by 12-fold (1.08 log units), on the high side; the whole stated range lies above it.
By their numbers in this assay, from the lowest: compound 4; then compound 1; then compound 2. At a limit, above all of these: compound 3.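

Hydroxy in place of 2-aminophenyl on the amide-type nitrogen gives an at least 14000-fold lower number from compound 3 to compound 4 (4.15 log units; beyond the scatter) in this assay, and this size is only a lower bound, as compound 3 stands at a limit: the limit of > 30000 nM in this assay, at which 1 of the 4 values shown sits. Ethyl in place of tert-butyl on the oxygen does not act in one direction: with hydroxy on the amide-type nitrogen it gives a 2.7-fold lower number from compound 1 to compound 4 (0.43 log units; beyond the scatter), while with 2-aminophenyl the number rose, so its effect depends on the group on that nitrogen: the same change on two cores in this assay, an at least 5.6-fold higher number (0.75 log units; beyond the scatter) from compound 2 to compound 3 and a 2.7-fold lower number (0.43 log units; beyond the scatter) from compound 1 to compound 4, at least 15-fold (1.18 log units) apart, beyond the scatter of two such steps. The exchange on the nitrogen likewise differs in size between the two cores: the same change on two cores in this assay, a 930-fold higher number (2.97 log units; beyond the scatter) from compound 1 to compound 2 and an at least 14000-fold higher number (4.15 log units; beyond the scatter) from compound 4 to compound 3, at least 15-fold (1.18 log units) apart, beyond the scatter of two such steps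

As far as these compounds go, how a methyl group on that oxygen, or a free amine in place of the whole carbamate, would behave with hydroxy on the nitrogen stays open. The data show that the two changes depend on each other. They do not explain this dependence.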